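The source may hold more compounds than are shown below. What is called first, only, known or untested is meant among the compounds shown, and "the series" means these compounds.

Measured compounds:
Compound 1, `O=C(/C=C/CN1CCCCC1)Nc1ccccc1`, in an ADME assay for pharmacokinetics, read by LC-MS, in phosphate buffer, with a stated time of 120 min, at pH 7.4, tested at 1 uM, in the presence of a further agent that is not named here (a higher number here means that the compound lasts longer, a lower number that the compound disappears faster), gives 2.95 h.
Compound 2, `C=C(F)C(=O)Nc1ccccc1`, in this assay reaches only > 8.53 h, which is a limit of the measurement and not a number.
Compound 3, `O=C(O)C/C=C/C(=O)Nc1ccccc1`, in this assay likewise reaches only > 8.53 h, again a limit.

Where compound 3 stands: only a limit is known for it. Among the compounds with values here, two of the three values shown sit at the limit of > 8.53 h in this assay, at which 2 of the 3 values shown sit, so compound 3 cannot be set in order against compound 2; against compound 1 the single available comparison is the measured step of an at least 2.8-fold higher number from compound 1 to compound 3 (0.46 log units; beyond the scatter).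

Compound 4, `O=C(/C=C/CF)Nc1ccccc1`, is not yet measured in this assay. It differs from compound 3 as follows: fluoro in place of carboxy on a saturated chain carbon bound to a double-bonded chain carbon.

Within the data shown here, only one measured step touches the saturated chain carbon bound to a double-bonded chain carbon: an at least 2.8-fold higher number from compound 1 to compound 3 (0.46 log units; beyond the scatter), which exchanged one substituent there and raised the number at least modestly. Among the measured compounds shown here, no measured pair exchanges carboxy for fluoro, so that step cannot be read off directly. Compound 2 carries fluoro at a different place and sits at the limit. The expectation is therefore that compound 4 remains long-lived, and the step of an at least 1.3-fold lower number from compound 3 to compound 4 (0.11 log units; that floor lies within the scatter) is expected to be small or none beyond the scatter. For compound 4 the estimate is 6.5 h, ranging from 2.5 h to 12 h.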

Compound 4, half-life: > 8.53 h
Compound 4: no number, only a limit (the forecaster's own chance of this, stated with the estimate: 45%); middle value at least 1.3-fold (0.11 log units) from the limit.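

In this assay, exchanging piperidin-1-yl on the saturated chain carbon bound to a double-bonded chain carbon now has a second readable outcome: fluoro there gives an at least 2.8-fold higher number from compound 1 to compound 4 (0.46 log units; beyond the scatter), which matches the floor that carboxy gave with an at least 2.8-fold higher number from compound 1 to compound 3 (0.46 log units; beyond the scatter). The half-life of compound 4 is known only as a limit, > 8.53 h, and not as a number. The steps to compound 4 from compound 3 and from compound 2 cannot be read, so fluoro and carboxy at this place cannot be put in order, nor can 3-fluoroprop-1-en-1-yl and 1-fluoroethenyl on the carbonyl carbon, and the series now stands largely at one ceiling: the limit of > 8.53 h in this assay, at which 3 of the 4 values shown sit.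

Only compound 1 gives a number, 2.95 h, so the series still cannot show whether the shorter half-life is tied to piperidin-1-yl alone or would also appear with another amine, such as dimethylamino or morpholin-4-yl, at this place. Any difference among compound 2, compound 3 and compound 4 also remains open, and a hydroxy group at this place would add a further neutral comparison with fluoro.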